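The compounds below may be only part of what the source reports. "The series", "measured", "known", "first", "only" and "open" are said of these compounds alone.

Compound 1, `CC(=O)c1cccc(-c2sc(N)c(C(=O)c3ccccc3)c2-c2cccc(C(F)(F)F)c2)c1`: in a functional assay on CHO-K1 cells for agonist activity at adenosine receptor A1 (Homo sapiens), read by GTPgammaS binding (on this read-out lower numbers stand for an effect already at smaller amounts and higher numbers for an effect only at larger amounts of compound), compound 1 gives > 10 uM, a limit of the assay rather than a number.
Compound 2, `Nc1sc(-c2ccc(Cl)cc2)c(-c2cccc(C(F)(F)F)c2)c1C(=O)c1ccccc1`: compound 2 gives > 10 uM, again only a limit.
Compound 3, `COc1ccc(-c2sc(N)c(C(=O)c3ccccc3)c2-c2cccc(C(F)(F)F)c2)cc1`: compound 3 gives > 10 uM, also a limit.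

The three compounds share one core and differ only in the group attached to the five-membered ring. Because all three values sit at the limit of > 10 uM in this assay, at which 3 of the 3 values shown sit, the steps between them cannot be read: a step that the two limits leave unreadable from compound 1 to compound 2, a step that the two limits leave unreadable from compound 1 to compound 3 and a step that the two limits leave unreadable from compound 2 to compound 3 each run from one limit to another. Compound 3 therefore stands at the limit, and the two other values shown stand at the same limit.

Compound 4, `Nc1sc(Cl)c(-c2cccc(C(F)(F)F)c2)c1C(=O)c1ccccc1`, is reached by chloro in place of 4-methoxyphenyl on an aromatic carbon. No measured step speaks readably to this change, since every step shown is bounded by limits on both sides. Among the measured compounds shown here, the expectation is accordingly that compound 4 behaves like the compounds measured so far, with a step that the limit leaves unreadable from compound 3 to compound 4 that does not rise above the scatter. Compound 4 is estimated at 20 uM in this assay, within a range from 5 uM to 100 uM, most likely reported again as a limit.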

Compound 4, concentration for half-maximal effect: > 10 uM
Compound 4 was reported as a limit; the forecaster's own chance of this, stated with the estimate: 75%; the middle value is on the limit's open side.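

In this assay compound 4 gives > 10 uM, again only a limit. Its steps from compound 1, compound 2 and compound 3 therefore cannot be read: the limit of > 10 uM in this assay, at which 4 of the 4 values shown sit.

The compounds shown leave open whether chloro, 4-chlorophenyl, 4-methoxyphenyl and 3-acetylphenyl differ at all in this assay.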